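The source may hold more compounds than are shown below. What is called first, only, known or untested is meant among the compounds shown, and "the series" means these compounds.

Working notes on the series, measured in a functional assay on CHO-K1 cells for antagonist activity at transient receptor potential cation channel subfamily V member 1 (Homo sapiens), read by FLIPR; a lower number here means a stronger inhibitor, a higher number a weaker inhibitor.

Compound 1 `CCCCNc1nc(C(F)(F)F)ccc1CNC(=O)C(C)c1ccc(NS(C)(=O)=O)c(F)c1` carries butyl on a nitrogen on an aromatic ring; in this assay compound 1 gives 293 nM. Among the measured compounds shown here, compound 2 `Cc1ccc(Nc2nc(C(F)(F)F)ccc2CNC(=O)C(C)c2ccc(NS(C)(=O)=O)c(F)c2)cc1C` carries 3,4-dimethylphenyl in that place, and in this assay compound 2 gives 1160 nM, the highest of the two numbers so far, with compound 1 as its only neighbour. For the measured compounds named here, the single step recorded at this position is a 4.0-fold higher number from compound 1 to compound 2 (0.60 log units; beyond the scatter), a modest rise.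

Compound 3 `CC(C(=O)NCc1ccc(C(F)(F)F)nc1NCc1ccc(Cl)cc1)c1ccc(NS(C)(=O)=O)c(F)c1` differs from compound 2 in one place: 4-chlorobenzyl in place of 3,4-dimethylphenyl on a nitrogen on an aromatic ring. Going by the values given here, no measured pair contains 4-chlorobenzyl, so the only guidance is the step from compound 1 to compound 2, which shows that exchanging one group on this nitrogen for another can move the number beyond the scatter, and that the 3,4-dimethylphenyl version sits at the weaker end. Replacing it with 4-chlorobenzyl is expected to give a modest step downward, of the order of a 2.3-fold lower number from compound 2 to compound 3 (0.37 log units; beyond the scatter), though a result within the scatter cannot be excluded. Compound 3 is therefore estimated at 500 nM, with a range of 150 nM to 1800 nM.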

Compound 3, half-maximal inhibitory concentration: 414 nM
The estimate for compound 3 lay 1.2-fold (0.08 log units) above the measured number; low and high end bracket the measured number.
By their numbers in this assay, from the lowest: compounds 1 and 3 (each within the scatter of the next); then compound 2.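

In this assay, 4-chlorobenzyl in place of 3,4-dimethylphenyl gives a 2.8-fold lower number from compound 2 to compound 3 (0.45 log units; beyond the scatter), so this nitrogen can also move the number downward from the level of compound 2. Exchanging butyl for 4-chlorobenzyl gives a 1.4-fold higher number from compound 1 to compound 3 (0.15 log units; within the scatter), which shows that a six-membered aromatic ring can be present in this place without a rise beyond the scatter; among these three compounds, the two with a saturated chain carbon bound to the nitrogen stay within the scatter of each other, while compound 2, which lacks that carbon, has the highest number. Nothing measured on these compounds accounts for either step.

The step from compound 2 to compound 3 changes the link to the ring and its substituents together, so the compounds shown cannot say which of the two matters; plain benzyl and 4-chlorophenyl on the same nitrogen would separate them. As far as these compounds go, how the number responds to a longer chain, or to a chain ending in an amine or a carboxylic acid, also remains open.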